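Trading a Dimethylamino for a Methyl on the Aryl

The source may report more compounds than this note shows. Statements on the series, on what has been measured and on what is new or still open speak of the compounds shown alone.

Three analogues sharing one core were tested in a functional assay on SW-620 cells (Homo sapiens) for cytotoxicity, read by sulforhodamine B assay, with a stated time of 48 h; on this read-out higher numbers stand for weaker inhibition and lower numbers for stronger inhibition. Compound 1 `C[C@H]1CC[C@@H]2[C@@H](OC(=O)[C@]23CC(c2ccccc2Br)=NO3)[C@]2(C)C(=O)C=C[C@@]12O` gives 44000 nM, compound 2 `C[C@H]1CC[C@@H]2[C@@H](OC(=O)[C@]23CC(c2ccc(N(C)C)cc2)=NO3)[C@]2(C)C(=O)C=C[C@@]12O` gives 5100 nM, and compound 3 `COc1ccc(C2=NO[C@]3(C2)C(=O)O[C@@H]2[C@H]3CC[C@H](C)[C@]3(O)C=CC(=O)[C@@]23C)cc1OC` gives 86000 nM. Among these three, compound 2 stands lowest, and its steps to both others lie beyond the scatter. Compound 4 `Cc1ccc(C2=NO[C@]3(C2)C(=O)O[C@@H]2[C@H]3CC[C@H](C)[C@]3(O)C=CC(=O)[C@@]23C)cc1` differs from compound 2 in one place: methyl in place of dimethylamino on an aromatic carbon. Among the compounds with values here, no measured step swaps a dimethylamino for a methyl, but two steps show how much the aryl substituent matters here: an 8.6-fold lower number from compound 1 to compound 2 (0.94 log units; beyond the scatter) and a 17-fold higher number from compound 2 to compound 3 (1.23 log units; beyond the scatter). Every change away from the dimethylamino so far has pushed the number up, so a rise beyond the scatter is expected again, though a smaller one. Compound 4 is therefore estimated at 30000 nM, within 8000 nM to 90000 nM, which would mean an expected 5.9-fold higher number from compound 2 to compound 4 (0.77 log units; beyond the scatter).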

Compound 4, half-maximal inhibitory concentration: 2500 nM
Compound 4: middle estimate off by 12-fold (1.08 log units), on the high side; the whole stated range lies above it.
By their numbers in this assay, from the lowest: compound 4; then compound 2; then compounds 1 and 3 (each within the scatter of the next).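

In this assay the dimethylamino group proves unnecessary at this position, since putting methyl there gives a 2.0-fold lower number from compound 2 to compound 4 (0.31 log units; beyond the scatter) and makes compound 4 the most potent of the four. A nitrogen-bearing group is therefore not required on the aryl ring, and the simple 4-methylphenyl also clearly outperforms the other two aryl groups, with a 34-fold lower number from compound 3 to compound 4 (1.54 log units; beyond the scatter) and with an 18-fold lower number from compound 1 to compound 4 (1.25 log units; beyond the scatter) in the same direction. Nothing available explains why methyl does better here. Going by these compounds, whether an ethyl, a chlorine or a carboxylic acid in the same place would lower the number further remains open.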